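A methyl on the amide-type nitrogen of compound 1

This account rests on a few compounds, and the source may have more. Where it says the series, first, only, none or still open, it means among the compounds named here.

Measured in a functional assay on thoracic aorta (Rattus norvegicus, strain Wistar), with a stated time of 15 min; a lower number here means that less compound is needed, a higher number that more compound is needed for the effect:
Compound 1 `Cc1ccc(OCc2ccccc2)c(C(C)NC(=O)NS(=O)(=O)c2ccc(Cl)cc2)c1`: 65300 nM
Compound 2 `CC(NC(=O)NS(=O)(=O)c1ccc(Cl)cc1)c1ccccc1OCc1ccccc1`: 157000 nM

Compound 1 holds the lower of the two numbers in this assay. Compound 3 `Cc1ccc(OCc2ccccc2)c(C(C)NC(=O)N(C)S(=O)(=O)c2ccc(Cl)cc2)c1` differs from it by methyl in place of hydrogen on an amide-type nitrogen. For the measured compounds named here, the only measured step, a 2.4-fold higher number from compound 1 to compound 2 (0.38 log units; beyond the scatter), is modest and concerns hydrogen in place of methyl on an aromatic carbon, so no measurement touches this nitrogen. A modest move towards a higher number is expected, though its direction is uncertain. The expected step is a 1.7-fold higher number from compound 1 to compound 3 (0.23 log units; within the scatter). For compound 3 the estimated value is 110000 nM, with an expected range from 35000 nM to 350000 nM.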

Compound 3, half-maximal effective concentration: 142000 nM
Compound 3: middle estimate off by 1.3-fold (0.11 log units), on the low side; measured number inside the range.
By their numbers in this assay, from the lowest: compound 1; then compounds 3 and 2 (each within the scatter of the next).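

For the compounds shown here, this is the first measurement at the amide-type nitrogen whose other neighbours are the carbonyl carbon and the sulfonyl sulfur. In this assay, methyl in place of hydrogen there gives a 2.2-fold higher number from compound 1 to compound 3 (0.34 log units; beyond the scatter), so a change at this nitrogen moves the number beyond the scatter, though only modestly. Nothing available accounts for this shift. On these data alone, it remains open whether an ethyl group or a longer chain on this nitrogen would move the number further, and whether the same methyl would have a similar effect in compound 2.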